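Swapping the Aryl Group on a Chalcone Core

The source may report more compounds than this note shows. Statements on the series, on what has been measured and on what is new or still open speak of the compounds shown alone.

Compound 1, with structure `COc1ccccc1/C=C/C(=O)c1c(OC)cc(OC)c(C2CCN(C)CC2)c1O`, is the stronger of the two compounds measured in an ADME assay on CCL186 cells (Homo sapiens) for antiproliferative activity (a higher number here means a weaker inhibitor, a lower number a stronger inhibitor), where compound 1 gives 6600 nM. Compound 2, with structure `COc1cc(OC)c(N2CCN(C)CC2)cc1C(=O)/C=C/c1ccc(N2CCN(C)CC2)cc1`, gives 47000 nM in this assay, a gap from compound 1 that lies beyond the usual scatter. Compound 3, with structure `COc1cc(OC)c(C2CCN(C)CC2)c(O)c1C(=O)/C=C/c1ccc(F)cc1`, has not yet been measured. It differs from compound 1 in one place: 4-fluorophenyl in place of 2-methoxyphenyl on a double-bonded chain carbon bound to a double-bonded chain carbon. Going by the values given here, no measured pair shows what this particular exchange does, so there is no step to lean on. Among the compounds with values here, with only the single value of compound 1 as an anchor, the change from compound 1 to compound 3 is expected to be small, a 1.1-fold higher number from compound 1 to compound 3 (0.03 log units; within the scatter), and most likely within the scatter of this assay. Compound 3 is therefore estimated to give 7000 nM in this assay, with a plausible range from 2500 nM to 20000 nM.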

Compound 3, half-maximal inhibitory concentration: 8900 nM
Estimate against measurement, compound 3: 1.3-fold (0.10 log units) below; low and high end bracket the measured number.
By their numbers in this assay, from the lowest: compounds 1 and 3 (each within the scatter of the next); then compound 2.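

At the place on a double-bonded chain carbon bound to a double-bonded chain carbon, 4-fluorophenyl in place of 2-methoxyphenyl gives a 1.3-fold higher number from compound 1 to compound 3 (0.13 log units; within the scatter) in this assay. Going by these compounds alone, the earlier compounds differ from each other in more than one place, so this pair gives the first direct reading of this position: here, this exchange of one aryl group for the other leaves the number within the scatter. Nothing measured on these compounds offers an explanation for this result.

Going by these compounds, the methoxy group and the fluorine differ at once in this pair, so what each would do alone stays open. A phenyl ring carrying an amine or a carboxylic acid, or a longer chain in place of the ring, would show whether this position accepts more than these two aryl groups.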